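Halogen swap on the amide of compound 2

The source may report more compounds than this note shows. Statements on the series, on what has been measured and on what is new or still open speak of the compounds shown alone.

Among the measured compounds shown here, compound 2 `O=C(CSc1nnc(NC(=O)CCl)s1)Nc1ccc(Cl)cn1` is the only member of this small series with a measured number: in a functional assay on A875 cells (Homo sapiens) for antiproliferative activity, read by MTT assay, with a stated time of 48 h (a lower number here means a stronger inhibitor, a higher number a weaker inhibitor), compound 2 gives 8600 nM. Compound 1 `COc1ccccc1C(=O)Nc1nnc(SCC(=O)Nc2ccc(Br)cn2)s1` carries a different acyl group on the shared core, and in this assay compound 1 gives only a limit, > 80000 nM, at which one of the two values sits (the limit of > 80000 nM in this assay, at which 1 of the 2 values shown sits). For the measured compounds named here, no step between the two measured compounds is given, so nothing further is read from that pair.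

Compound 3 `O=C(CSc1nnc(NC(=O)CCl)s1)Nc1ccc(Br)cn1` differs from compound 2 by bromo in place of chloro on an aromatic carbon, in words bromo in place of chloro on an aromatic carbon. A change of this kind on compound 2 is expected to shift this assay by no more than the usual scatter, in no fixed direction, so the step of a 1.1-fold lower number from compound 2 to compound 3 (0.03 log units; within the scatter) is estimated to be small. Compound 3 is accordingly expected to give 8000 nM in this assay, within a range from 3000 nM to 25000 nM.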

Compound 3, half-maximal inhibitory concentration: 13900 nM
The estimate for compound 3 lay 1.7-fold (0.24 log units) below the measured number; measured number inside the range.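

In this assay, the change from 5-chloropyridin-2-yl to 5-bromopyridin-2-yl stays within the scatter (a 1.6-fold higher number from compound 2 to compound 3 (0.21 log units; within the scatter)), so these two halogens cannot be told apart at this position. Among the compounds shown here, with bromo held fixed, compound 1 and compound 3 give the first comparison at the acyl end, where chloromethyl in place of 2-methoxyphenyl on a carbonyl carbon gives a step beyond the scatter (an at least 5.7-fold lower number from compound 1 to compound 3 (0.76 log units; beyond the scatter)). The value of compound 1 is a limit and not a number, so the size of that step is only a bound: the limit of > 80000 nM in this assay, at which 1 of the 3 values shown sits.

As far as these compounds go, whether the step is specific to chloromethyl or extends to other acyl groups remains open, as does the reach of this position beyond chloro and bromo. An amine or a carboxylic acid in place of the bromo, or a longer chain in place of chloromethyl, would bear on these points.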